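Bromine on the five-membered ring of two benzyl-type purine amines

The source may hold more compounds than are shown below. What is called first, only, known or untested is meant among the compounds shown, and "the series" means these compounds.

Measured compounds:
compound 1 `CCCn1cnc2c(NCc3ccccc3)ncnc21` 29100 nM
compound 2 `CCCn1cnc2c(NCCCc3ccccc3)ncnc21` 30000 nM
compound 3 `CCCn1c(Br)nc2c(NCc3ccccc3)ncnc21` 11100 nM

Of the compounds shown here, three have been tested in an assay on CHO cells for displacement of a labelled ligand from transmembrane domain-containing protein TMIGD3 (Homo sapiens); on this read-out lower numbers stand for stronger inhibition and higher numbers for weaker inhibition. Compound 1 gives 29100 nM in this assay, and compound 2 gives 30000 nM; these two numbers are within the scatter of each other, so no order between them is claimed. The difference between the core of compound 1 and that of compound 2 is not broken down here.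

Compound 3 carries a single change relative to compound 1, (bromo in place of hydrogen on an aromatic carbon), and in this assay compound 3 gives 11100 nM. That change produced a 2.6-fold lower number from compound 1 to compound 3 (0.42 log units; beyond the scatter).

Compound 4 `CCCn1c(Br)nc2c(NCCCc3ccccc3)ncnc21` has not yet been measured. It differs from compound 2 by bromo in place of hydrogen on an aromatic carbon, the same change as that from compound 1 to compound 3, made at the same place in both pairs. Compound 4 is expected to show a 2.6-fold lower number from compound 2 to compound 4 (0.42 log units; beyond the scatter) in this assay, a step of about the same size as the earlier one, because the same change gave a 2.6-fold lower number from compound 1 to compound 3 (0.42 log units; beyond the scatter). This expectation rests on one measured pair alone. For compound 4 the estimated value in this assay is 11500 nM, with a likely range from 5000 nM to 26000 nM.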

Compound 4, inhibition constant: 12200 nM
Estimate against measurement, compound 4: 1.1-fold (0.03 log units) below, and the stated range covers the measured number.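

In this assay, bromo in place of hydrogen on an aromatic carbon gave a 2.5-fold lower number from compound 2 to compound 4 (0.39 log units; beyond the scatter), so the change also lowered the number on the second core. Set beside the earlier step, the size of the change carried over from one core to the other with no difference beyond the scatter: the same change on two cores in this assay, a 2.6-fold lower number (0.42 log units; beyond the scatter) from compound 1 to compound 3 and a 2.5-fold lower number (0.39 log units; beyond the scatter) from compound 2 to compound 4, 1.1-fold (0.03 log units) apart, within the scatter of two such steps. Among these compounds, this agreement rests on only two pairs of closely related compounds in a single read-out, and it does not show that the step would keep its size on a more distant core or in any other assay.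

The compounds shown leave open whether chloro, iodo or an amine on the same aromatic carbon would give a step of similar size to that of bromo. They also leave open whether the bromo step would hold with a longer chain, such as butyl, in place of the propyl group.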